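Aryl variation at the benzylic indole nitrogen substituent

The source may hold more compounds than are shown below. What is called first, only, known or untested is meant among the compounds shown, and "the series" means these compounds.

Measured compounds:
- compound 1, `C/C(=C\C(=O)Nc1ccccc1OCCCC(=O)O)c1ccc2c(ccn2C(C)c2ccccc2)c1`: 19 nM
- compound 2, `C/C(=C\C(=O)Nc1ccccc1OCCCC(=O)O)c1ccc2c(ccn2C(c2ccccc2)c2ccc(C(F)(F)F)cc2)c1`: 8.1 nM
- compound 3, `C/C(=C\C(=O)Nc1ccccc1OCCCC(=O)O)c1ccc2c(ccn2C(c2ccccc2)c2ccccn2)c1`: 37 nM

All three share one core and differ only in the group on a saturated chain carbon bound to an aromatic carbon and an aromatic nitrogen. In an assay on Prostate gland for inhibition of steroid 5-alpha-reductase (Rattus norvegicus) (on this read-out lower numbers stand for stronger inhibition and higher numbers for weaker inhibition), compound 3 gives the highest of the three numbers; the step of a 1.9-fold higher number from compound 1 to compound 3 (0.29 log units; within the scatter) lies within the scatter, whereas the step of a 4.6-fold higher number from compound 2 to compound 3 (0.66 log units; beyond the scatter) does not. Compound 4, `C/C(=C\C(=O)Nc1ccccc1OCCCC(=O)O)c1ccc2c(ccn2C(c2ccccc2)c2ccncc2)c1`, differs from compound 3 by pyridin-4-yl in place of pyridin-2-yl on a saturated chain carbon bound to an aromatic carbon and an aromatic nitrogen. Among the measured compounds shown here, no measured step moves the ring nitrogen within the same six-membered aromatic ring; the steps seen so far, a 2.3-fold lower number from compound 1 to compound 2 (0.37 log units; beyond the scatter) and a 1.9-fold higher number from compound 1 to compound 3 (0.29 log units; within the scatter), exchange methyl for a whole aryl group and are modest or within the scatter. The ring count, atom count and acceptor count stay the same here, so no step beyond the scatter is expected in this assay. The step of a 1.1-fold lower number from compound 3 to compound 4 (0.02 log units; within the scatter) is the estimated outcome. Compound 4 is expected to give about 35 nM, in the range 12 nM to 100 nM.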

Compound 4, half-maximal inhibitory concentration: 26 nM
Compound 4: the middle estimate sits 1.3-fold (0.13 log units) above what was measured, and the stated range covers the measured number.
By their numbers in this assay, from the lowest: compound 2; then compounds 1, 4 and 3 (each within the scatter of the next).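

Moving the ring nitrogen, with pyridin-4-yl in place of pyridin-2-yl, is the first change here that keeps the same atoms and only joins them differently, and in this assay it gives a 1.4-fold lower number from compound 3 to compound 4 (0.15 log units; within the scatter) and so does not separate the two pyridine isomers at this position. The 4-(trifluoromethyl)phenyl group stays apart from both pyridines, with a 3.2-fold higher number from compound 2 to compound 4 (0.51 log units; beyond the scatter) beside the earlier 4.6-fold higher number from compound 2 to compound 3 (0.66 log units; beyond the scatter) as its counterpart, while a 1.4-fold higher number from compound 1 to compound 4 (0.14 log units; within the scatter) places pyridin-4-yl alongside methyl as well. No measured evidence on the origin of these steps is at hand.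

As far as these compounds go, whether pyridin-3-yl also falls with the two pyridine isomers remains open. From the compounds shown here alone, it is equally open whether a second unsubstituted phenyl on the same carbon would sit with compound 2 or with the pyridines.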